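The source may report more compounds than this note shows. Statements on the series, on what has been measured and on what is new or still open speak of the compounds shown alone.

Measured compounds, with their numbers in a functional assay on HL-60 cells (Homo sapiens) for cytotoxicity, read by WST assay, with a stated time of 48 h; on this read-out lower numbers stand for stronger inhibition and higher numbers for weaker inhibition:
compound 1 `O=[N+]([O-])c1ccccc1/C=C/C[C@H]1C[C@@H]([C@@H](O)c2ccccc2)CO[C@@H]1c1ccccc1`: 7250 nM
compound 2 `O[C@@H](c1ccccc1)[C@H]1CO[C@H](c2ccccc2)[C@@H](C/C=C/c2ccccc2)C1`: 7040 nM
compound 3 `C=CC[C@H]1C[C@@H]([C@@H](O)c2ccccc2)CO[C@@H]1c1ccccc1`: 36000 nM

In this assay compound 3 stands highest of the three, beyond the scatter from both compound 1 and compound 2, so it is the weakest inhibitor of the set so far.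

Compound 4 `O[C@@H](c1ccccc1)[C@H]1CO[C@H](c2ccccc2)[C@@H](C/C=C/c2ccccc2F)C1` differs from compound 3 in one place: 2-(2-fluorophenyl)ethenyl in place of vinyl on a saturated chain carbon bound to a saturated ring carbon

For the measured compounds named here, two measured steps bear on this. The step of a 5.1-fold higher number from compound 2 to compound 3 (0.71 log units; beyond the scatter) is the same change run backwards without the fluorine, and gives the size to expect when the aryl-bearing chain is restored. The step of a 1.0-fold lower number from compound 1 to compound 2 (0.01 log units; within the scatter) shows that swapping a substituent on the aromatic carbon of that chain left the number unchanged, so the fluorine is expected to add little on top. For compound 4 a step of about a 5.1-fold lower number from compound 3 to compound 4 (0.71 log units; beyond the scatter) in this assay is therefore expected, downward, of the same size as the measured step. Compound 4 is estimated at 7000 nM, with a range of 3500 nM to 14000 nM.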

Compound 4, half-maximal inhibitory concentration: 9530 nM
Compound 4: middle estimate off by 1.4-fold (0.13 log units), on the low side; low and high end bracket the measured number.
By their numbers in this assay, from the lowest: compounds 2, 1 and 4 (each within the scatter of the next); then compound 3.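

In this assay there is a 3.8-fold lower number from compound 3 to compound 4 (0.58 log units; beyond the scatter) when 2-(2-fluorophenyl)ethenyl replaces vinyl on the saturated chain carbon, so the aryl-bearing chain again gives a lower number than vinyl, now with a substituted aromatic ring, in the same direction as the reverse of a 5.1-fold higher number from compound 2 to compound 3 (0.71 log units; beyond the scatter) on the unsubstituted chain. Fluoro also does not separate from hydrogen or nitro on that aromatic ring: a 1.4-fold higher number from compound 2 to compound 4 (0.13 log units; within the scatter) and a 1.3-fold higher number from compound 1 to compound 4 (0.12 log units; within the scatter) both stay within the scatter, so the three compounds carrying the aryl-bearing chain form one level. No measured data at hand account for these steps.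

On these data alone, whether an amine or a carboxylic acid on that aromatic ring would break from this level remains open. So does the effect of a longer chain in place of 3-(2-fluorophenyl)prop-2-en-1-yl.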